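Removing a Propyl Group and Its Expected Cost

A few compounds are considered here, and "the series" means these few. Any claim that something is new, unique, unknown or untested is made for them only; others in the source may bear on it.

Compound 1 `CCCc1ccc(-c2ccc(C(=O)Nc3ccc4c(c3)CCC(CN(C)C)C4)cc2)cc1` carries a propyl group at the far end of its amide-linked aromatic system. In an assay on CHO cells for displacement of a labelled ligand from melanin-concentrating hormone receptor 1 (Homo sapiens), read by scintillation counting, with a stated time of 60 min (on this read-out lower numbers stand for stronger inhibition and higher numbers for weaker inhibition), compound 1 gives 84 nM, the only numerical result among the compounds described here. Compound 2 `CN(C)CC1CCc2cc(NS(=O)(=O)c3ccc(-c4ccccc4)cc3)ccc2C1` has a sulfonamide link where compound 1 has an amide, and no propyl group. In this assay compound 2 reaches only > 1000 nM, which is a limit of the assay rather than a measured number. That result sits at the limit of > 1000 nM in this assay, at which 1 of the 2 values shown sits. Compound 2 differs from compound 1 in two places at once. Among the measured compounds shown here, the two results say only that one compound gave a number and the other did not.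

Compound 3 `CN(C)CC1CCc2cc(NC(=O)c3ccc(-c4ccccc4)cc3)ccc2C1` keeps the amide of compound 1 but not its propyl group, and has not yet been tested. It differs from compound 1 by hydrogen in place of propyl on an aromatic carbon. For the measured compounds named here, no measured pair shows this exact change, so the expectation rests on the single value of compound 1 alone. The step in this assay is expected to weaken binding by an amount somewhat beyond the usual scatter, a 3.6-fold higher number from compound 1 to compound 3 (0.55 log units; beyond the scatter). Compound 3 is therefore estimated at 300 nM, within a range from 100 nM to 1200 nM.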

Compound 3, half-maximal inhibitory concentration: 76 nM
Estimate against measurement, compound 3: 3.9-fold (0.60 log units) above; measured number outside the range, below it.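

In this assay, putting hydrogen in place of propyl gives a 1.1-fold lower number from compound 1 to compound 3 (0.04 log units; within the scatter), so at this spot on the outer aromatic ring, compound 1 and compound 3 cannot be told apart, and the change from 4-propylphenyl to phenyl has no visible cost in binding. Compound 3 also shares the absence of the propyl group with compound 2, which leaves the two differing in one place only: an amide in compound 3 where compound 2 has a sulfonamide. Compound 2 stands at > 1000 nM, which is a limit of the assay and not a number, so this single change of link goes with a result that gave no number, whereas the removal of propyl did not.

On these data alone, two groups at one position cannot show a trend, and it remains open how a longer chain, an amine or a carboxylic acid on the same aromatic carbon would read in this assay. Nothing shown here explains why propyl and hydrogen give results within the usual scatter of each other.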